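Paired fluoro variants of a shared anilide core

A few compounds are considered here, and "the series" means these few. Any claim that something is new, unique, unknown or untested is made for them only; others in the source may bear on it.

Measured compounds:
compound 1 `O=C(Nc1ccc(Oc2ccnc3[nH]ccc23)cc1)c1cc2cccnc2n(-c2ccc(F)cc2)c1=O` 1360 nM
compound 2 `O=C(Nc1ccc(Oc2ccnc3[nH]ccc23)c(F)c1)c1cc2cccnc2n(-c2ccccc2)c1=O` 1260 nM

In a functional assay on U-87MG ATCC cells for antiproliferative activity against U-87 MG (Homo sapiens), read by MTT assay, with a stated time of 72 h (on this read-out lower numbers stand for stronger inhibition and higher numbers for weaker inhibition), compound 1 gives 1360 nM and compound 2 gives 1260 nM. Compound 2 stands alongside compound 1: the two numbers lie within the scatter of each other, so no order between them is claimed.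

Compound 3 `O=C(Nc1ccc(Oc2ccnc3[nH]ccc23)c(F)c1)c1cc2cccnc2n(-c2ccc(F)cc2)c1=O` is not yet measured. Against compound 2 the change is fluoro in place of hydrogen on an aromatic carbon. Compound 1 already carries this fluoro and sits within the scatter of compound 2, so no step beyond the scatter is expected. The expected step is a 1.1-fold lower number from compound 2 to compound 3 (0.04 log units; within the scatter). Compound 3 is estimated at 1150 nM, within 500 nM to 2600 nM.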

Compound 3, half-maximal inhibitory concentration: 620 nM
Compound 3: the middle estimate sits 1.9-fold (0.27 log units) above what was measured, and the stated range covers the measured number.
By their numbers in this assay, from the lowest: compound 3; then compounds 2 and 1 (each within the scatter of the next).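

In this assay, phenyl to 4-fluorophenyl gives a 2.0-fold lower number from compound 2 to compound 3 (0.31 log units; beyond the scatter), and the other fluoro gives a 2.2-fold lower number from compound 1 to compound 3 (0.34 log units; beyond the scatter). Each fluoro therefore lowers the number when added to a compound already carrying the other, a modest effect that the earlier pair could not reveal. Nothing here bears on the reason for either step.

Open, from the compounds shown here alone, is how the series reads with neither fluoro present. Also open, going by these compounds, is whether chloro, methoxy or an amine para to the large group would match the 4-fluorophenyl result.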